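From 3,4-dimethylphenyl to 4-bromophenyl in a cytotoxic series

The compounds below may be only part of what the source reports. "The series", "measured", "known", "first", "only" and "open" are said of these compounds alone.

Of the compounds shown here, three with a closely related core have been measured in a functional assay on NCI-H520 cells (Homo sapiens) for cytotoxicity; a lower number here means a stronger inhibitor of growth, a higher number a weaker inhibitor of growth. Compound 1 `COc1ccc(C2=C(c3cc(OC)c(OC)c(OC)c3)CC3CCCN3C2=O)cc1O` gives > 100000 nM, which is a limit of the assay and not a number. Compound 2 `COc1ccc(C2=C(c3ccc(SC)cc3)CC3CCCN3C2=O)cc1OC(=O)CNC(=O)OC(C)(C)C` gives 7000 nM. Compound 3 `CSc1ccc(C2=C(c3ccc(C)c(C)c3)C(=O)N3CCCC3C2)cc1` gives 300 nM, the lowest number shown, and its gap to compound 2 lies beyond the scatter.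

Compound 4 `CSc1ccc(C2=C(c3ccc(Br)cc3)C(=O)N3CCCC3C2)cc1` carries 4-bromophenyl in place of 3,4-dimethylphenyl on a double-bonded ring carbon, next to the ring atom that bears a 4-(methylsulfanyl)phenyl group: 4-bromophenyl in place of 3,4-dimethylphenyl on a double-bonded ring carbon. For the measured compounds named here, no measured pair in this assay isolates this exchange, so the expectation rests mainly on compound 3 at 300 nM. The expected change is small, a 1.7-fold higher number from compound 3 to compound 4 (0.22 log units; within the scatter), and it is not expected to exceed the scatter. For compound 4 the estimated value in this assay is 500 nM, with an expected range from 100 nM to 3000 nM.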

Compound 4, concentration for 50% growth inhibition: 7000 nM
Beside the measured number, compound 4's estimate is 14-fold (1.15 log units) below it, outside the stated range (above it).
By their numbers in this assay, from the lowest: compound 3; then compounds 2 and 4 (each within the scatter of the next). At a limit, above all of these: compound 1.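

In this assay, the double-bonded ring carbon proves sensitive to the group it carries, as 4-bromophenyl in place of 3,4-dimethylphenyl gives a 23-fold higher number from compound 3 to compound 4 (1.37 log units; beyond the scatter). For the compounds shown here, the earlier compounds offered no pair differing in one place, so this is the first direct reading of any single exchange. The two groups match in each being one six-membered aromatic ring of carbon only, with no hydrogen-bond donors or acceptors and no net charge, yet the step is large; the compounds shown offer no measured property that accounts for it.

On these data alone, it remains open whether the step follows the entry of the bromine or the loss of the methyl groups, a question that 4-methylphenyl on the same carbon would address. As far as these compounds go, how a 4-aminophenyl group would read at this position also remains open.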